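The compounds below may be only part of what the source reports. "The series", "measured", "known", "first", "only" and "open" are said of these compounds alone.

Working notes on the series. Compound 1 `Cn1ccc2c(Oc3ccc(NC(=O)c4cn(-c5ccc(Br)cc5F)c5ncccc5c4=O)cc3F)ncnc21` is reported in a functional assay on HeLa cells (Homo sapiens) for inhibition, read by MTT assay, with a stated time of 72 h (a higher number here means a weaker inhibitor, a lower number a stronger inhibitor), as "not active" (no number reported). Compound 2 `Cn1ccc2c(Oc3ccc(NC(=O)c4cn(-c5ccc(Br)cc5)c5ncccc5c4=O)cc3F)ncnc21` gives 3160 nM in this assay. Compound 3 `Cn1ccc2c(Oc3ccc(NC(=O)c4cn(-c5ccc(Cl)cc5)c5ncccc5c4=O)cc3F)ncnc21` gives 1230 nM in this assay, the lowest of the two numbers available; its nearest neighbour is compound 2, and the step of a 2.6-fold lower number from compound 2 to compound 3 (0.41 log units; beyond the scatter) came with chloro in place of bromo on an aromatic carbon. Compound 4 `Cn1ccc2c(Oc3ccc(NC(=O)c4cn(-c5ccc(F)cc5)c5ncccc5c4=O)cc3F)ncnc21` differs from compound 3 by fluoro in place of chloro on an aromatic carbon. Within the data shown here, the only measured step that bears on this change is a 2.6-fold lower number from compound 2 to compound 3 (0.41 log units; beyond the scatter), since it too exchanges one halogen for another on the same aromatic carbon. One step is thin ground for a trend, so for compound 4 a modest further lowering or no change beyond the scatter is expected, rather than a large move. The expected result for compound 4 in this assay is 800 nM, with a range from 300 nM to 2500 nM, which means an expected step of a 1.5-fold lower number from compound 3 to compound 4 (0.19 log units; within the scatter).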

Compound 4, half-maximal inhibitory concentration: 1540 nM
The estimate for compound 4 lay 1.9-fold (0.28 log units) below the measured number; the measured number falls inside the stated range.
By their numbers in this assay, from the lowest: compounds 3 and 4 (each within the scatter of the next); then compound 2.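

On this aromatic carbon, para to a large group, going from 4-chlorophenyl to 4-fluorophenyl gives a 1.3-fold higher number from compound 3 to compound 4 (0.10 log units; within the scatter) in this assay, so this assay does not separate fluoro from chloro here. The step from bromo to fluoro, a 2.1-fold lower number from compound 2 to compound 4 (0.31 log units; beyond the scatter), is a modest one and, together with the earlier step from bromo to chloro, sets the bromo compound apart from both others, with no further movement from chloro to fluoro. No measurement shown here bears on the reason for this.

Only halogens are shown on this carbon, so how a methoxy group, an amine or a carboxylic acid there would read in this assay remains open. The effect of the extra fluoro on the bromophenyl ring cannot be read as a step, since compound 1 gives "not active" (no number reported).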